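Oxolane attachment point: compound 2 to compound 3

This account rests on a few compounds, and the source may have more. Where it says the series, first, only, none or still open, it means among the compounds named here.

For the measured compounds named here, compound 2 `Cc1cc(C)c(CN2CCc3c(Cl)cc([C@@H](CO)[C@@H]4CCOC4)c(Cl)c3C2=O)c(=O)[nH]1` gives 1260 nM in an assay for inhibition of histone-lysine N-methyltransferase EZH2 variant Y641N (Homo sapiens), read by scintillation counting, with a stated time of 60 min, in the presence of a further agent that is not named here (a higher number here means a weaker inhibitor, a lower number a stronger inhibitor), the only number it has there. Compound 1 `COC(c1cc(Cl)c2c(c1Cl)C(=O)N(Cc1c(C)cc(C)[nH]c1=O)CC2)C1CCS(=O)(=O)CC1` shows 93 nM; 0.35 nM (2 entries) in this assay, with entries far apart, as the record the several entries of compound 1 in this assay, 93 nM; 0.35 nM (2 entries) makes plain. Compound 3 `Cc1cc(C)c(CN2CCc3c(Cl)cc([C@@H](CO)[C@@H]4CCCO4)c(Cl)c3C2=O)c(=O)[nH]1` differs from compound 2 by oxolan-2-yl in place of oxolan-3-yl on a saturated chain carbon bound to an aromatic carbon and a saturated chain carbon. Going by the values given here, no step between measured compounds covers this change, so the expected step is a 1.3-fold lower number from compound 2 to compound 3 (0.10 log units; within the scatter), in either direction but not beyond the scatter. Compound 3 is therefore estimated at 1000 nM, within 300 nM to 4000 nM.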

Compound 3, inhibition constant: 135 nM
For compound 3 the middle estimate is 7.4-fold (0.87 log units) above the measured one; the measured number lies below the stated range.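

In this assay, moving the attachment point of the oxolane ring, with the same atoms throughout, changes the result beyond the scatter: a 9.3-fold lower number from compound 2 to compound 3 (0.97 log units; beyond the scatter). For the compounds shown here, the earlier compounds offered no step at this saturated chain carbon, so this is the first sign that the attachment point alone matters there. The reading rests on a single pair, and repeat entries in this assay can lie far apart: the several entries of compound 1 in this assay, 93 nM; 0.35 nM (2 entries).

Still open, on these data alone, is whether the step persists with the opposite configuration at the oxolan-2-yl ring stereocentre. Also open, as far as these compounds go, is how a pyrrolidin-2-yl amine would compare with oxolan-2-yl at this place.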